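Adding pyridin-4-yl to compound 3

The source may hold more compounds than are shown below. What is called first, only, known or untested is meant among the compounds shown, and "the series" means these compounds.

In a functional assay on COLO 205 cells (Homo sapiens) for cytotoxicity (a lower number here means a stronger inhibitor, a higher number a weaker inhibitor), compound 3 `Cc1cc(Nc2nn(C)c(=O)c3ccccc23)n[nH]1` shows only a limit of the assay, > 30000 nM. Two relatives give real numbers: compound 1 `Cc1cc(Nc2nn(Cc3cccnc3)c(=O)c3ccccc23)n[nH]1` reaches 4100 nM, and compound 2 `Cc1cc(Nc2nn(-c3ccc(F)cc3)c(=O)c3ccccc23)n[nH]1` reaches 1600 nM.

Compound 4 `Cc1cc(Nc2nn(Cc3ccncc3)c(=O)c3ccccc23)n[nH]1` is built from compound 3 by one change, (pyridin-4-yl in place of hydrogen on a saturated chain carbon bound to an aromatic nitrogen), which turns methyl into (pyridin-4-yl)methyl. The closest guide is the loss of pyridin-3-yl at that same place, which gave an at least 7.3-fold higher number from compound 1 to compound 3 (0.86 log units; beyond the scatter). Replacing 4-fluorophenyl with methyl at the aromatic nitrogen points the same way, with an at least 18-fold higher number from compound 2 to compound 3 (1.27 log units; beyond the scatter).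

A move to a lower number of at least modest size is therefore expected, and the estimate is an at least 6.6-fold lower number from compound 3 to compound 4 (0.82 log units; beyond the scatter). For compound 4 the expected value is 4500 nM, within an estimated range of 1500 nM to 14000 nM.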

Compound 4, half-maximal inhibitory concentration: 13000 nM
Compound 4: middle estimate off by 2.9-fold (0.46 log units), on the low side; low and high end bracket the measured number.
By their numbers in this assay, from the lowest: compound 2; then compound 1; then compound 4. At a limit, above all of these: compound 3.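

Pyridin-4-yl on the saturated chain carbon gives an at least 2.3-fold lower number from compound 3 to compound 4 (0.36 log units; beyond the scatter). Compound 3 sits at a limit of the assay rather than at a real number, so this step marks only the smallest possible gain: the limit of > 30000 nM in this assay, at which 1 of the 4 values shown sits. The two pyridinyl groups are not interchangeable here, since pyridin-4-yl in place of pyridin-3-yl gives a 3.2-fold higher number from compound 1 to compound 4 (0.50 log units; beyond the scatter), and (pyridin-4-yl)methyl also trails 4-fluorophenyl on the aromatic nitrogen, with an 8.1-fold higher number from compound 2 to compound 4 (0.91 log units; beyond the scatter).

From the compounds shown here alone, what phenyl or pyridin-2-yl on that same chain carbon would give remains open, so the role of the ring nitrogen is unsettled.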